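The source may report more compounds than this note shows. Statements on the series, on what has been measured and on what is new or still open speak of the compounds shown alone.

In a functional assay on MCF7 cells (Homo sapiens) for antiproliferative activity, read by sulforhodamine B assay, with a stated time of 72 h (on this read-out lower numbers stand for stronger inhibition and higher numbers for weaker inhibition), three compounds built on a shared core have been measured so far. Compound 1 `O=C(Cn1nc(-c2ccccc2)c2ccccc2c1=O)Nc1ccccc1` gives 43000 nM, compound 2 `O=C(Cn1nc(-c2ccccc2)c2ccccc2c1=O)Nc1cccc(Cl)c1` gives 74000 nM, and compound 3 `O=C(Cn1nc(Cc2ccccc2)c2ccccc2c1=O)Nc1ccccc1` gives 36000 nM. Compound 3 therefore lies within the scatter of compound 1, while its value and that of compound 2 lie just beyond the scatter of each other.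

Compound 4 `O=C(Cn1nc(Cc2ccccc2)c2ccccc2c1=O)Nc1cccc(C(F)(F)F)c1` differs from compound 3 by one change: trifluoromethyl in place of hydrogen on an aromatic carbon. This is trifluoromethyl in place of hydrogen on an aromatic carbon, turning phenyl into 3-(trifluoromethyl)phenyl. The closest measured precedent is chloro in place of hydrogen on an aromatic carbon, seen in a 1.7-fold higher number from compound 1 to compound 2 (0.24 log units; within the scatter). The other measured step, benzyl in place of phenyl, is a 1.2-fold lower number from compound 1 to compound 3 (0.08 log units; within the scatter). Neither step leaves the scatter, so no step beyond the scatter is expected here, with only a slight lean towards a higher number resting on compound 2. The expected step is a 1.3-fold higher number from compound 3 to compound 4 (0.10 log units; within the scatter). For compound 4 the estimated value is 45000 nM, with an expected range of 20000 nM to 95000 nM.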

Compound 4, half-maximal inhibitory concentration: 3850 nM
Estimate against measurement, compound 4: 12-fold (1.07 log units) above; measured number below the stated range.
By their numbers in this assay, from the lowest: compound 4; then compounds 3, 1 and 2 (each within the scatter of the next, the first and the last beyond it).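

In this assay, within the data shown here, trifluoromethyl in place of hydrogen on an aromatic carbon gives a 9.4-fold lower number from compound 3 to compound 4 (0.97 log units; beyond the scatter), the only step between compounds differing in one place that lies beyond the scatter. This shows that the number can respond to a substituent on this ring, whereas chloro, on the compound with phenyl in place of benzyl, gave only a 1.7-fold higher number from compound 1 to compound 2 (0.24 log units; within the scatter), within the scatter. Nothing measured here bears on why the number falls with trifluoromethyl.

The compounds shown leave open whether trifluoromethyl would give a similar step with phenyl in place of benzyl, and whether chloro would give one with benzyl present. They also leave open how an amine, a carboxylic acid or a methoxy group would read at this place on the ring.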